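A few compounds are considered here, and "the series" means these few. Any claim that something is new, unique, unknown or untested is made for them only; others in the source may bear on it.

In a physicochemical assay for solubility, tested at 500 uM (on this read-out higher numbers stand for higher solubility and lower numbers for lower solubility), compound 3 (`COc1ccccc1-c1nc(C)c(COc2ccc(CCC(=O)O)cc2)o1`) gives 400000 nM, and compound 2 (`COc1cccc(-c2nc(C)c(COc3ccc(CC(=O)O)cc3)o2)c1`) gives 410000 nM in the same read-out. Compound 3 and compound 2 stand within the scatter of each other. Compound 1 (`COC(=O)CCc1ccc(OCc2oc(-c3cccc(OC)c3)nc2C)cc1`) gives 38200 nM in the same read-out. Compound 3 stands beyond the scatter on the high side of compound 1. Compound 4 (`COc1cccc(-c2nc(C)c(COc3ccc(CCC(=O)O)cc3)o2)c1`) has 3-methoxyphenyl in place of 2-methoxyphenyl on an aromatic carbon of a five-membered aromatic ring with 1 nitrogen and 1 oxygen (3-methoxyphenyl in place of 2-methoxyphenyl on an aromatic carbon) and has not yet been measured. Among the measured compounds shown here, the only measured step is large (an 11-fold higher number from compound 1 to compound 2 (1.03 log units; beyond the scatter)) but it puts carboxy in place of (methoxycarbonyl)methyl and leaves the methoxyphenyl group unchanged, so it bears on this change only indirectly. For the measured compounds named here, no measured step makes this exchange itself. Compound 2 carries 3-methoxyphenyl together with carboxy and gives 410000 nM in this comparison, level with compound 3 within the scatter. A change beyond the scatter is therefore not expected, and the expected result in this assay is a 1.0-fold lower number from compound 3 to compound 4 (0.01 log units; within the scatter) as the step. For compound 4 the estimated value is 390000 nM with an expected range from 220000 nM to 500000 nM in this read-out.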

Compound 4, solubility: 234000 nM
Beside the measured number, compound 4's estimate is 1.7-fold (0.22 log units) above it, and the stated range covers the measured number.
By their numbers in this assay, from the lowest: compound 1; then compounds 4, 3 and 2 (each within the scatter of the next).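

On the aromatic carbon next to the ring nitrogen and next to the ring oxygen, 3-methoxyphenyl in place of 2-methoxyphenyl gives a 1.7-fold lower number from compound 3 to compound 4 (0.23 log units; within the scatter), so in this assay this exchange, now read directly, does not separate the two compounds, and carboxymethyl in place of carboxy likewise gives only a 1.8-fold lower number from compound 2 to compound 4 (0.24 log units; within the scatter). Hydrogen in place of methyl on an oxygen next to a carbonyl group gives a 6.1-fold higher number from compound 1 to compound 4 (0.79 log units; beyond the scatter), which shows that the higher number holds for this exchange alone, with the chain left unchanged, though the step is smaller than an 11-fold higher number from compound 1 to compound 2 (1.03 log units; beyond the scatter). No measurement is at hand that explains any of these results.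

The compounds shown leave open whether 4-methoxyphenyl or plain phenyl at this place would stay level with these compounds. They also leave open how a primary amide in place of the carboxylic acid would read.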